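Cytotoxicity notes on oxazolidinone side-chain variants

The source may report more compounds than this note shows. Statements on the series, on what has been measured and on what is new or still open speak of the compounds shown alone.

Measured so far:
compound 1 `CN1CCN(C[C@H]2CN(c3ccc(-n4cc(-c5ccccn5)cn4)c(F)c3)C(=O)O2)CC1`: 70 ug/mL
compound 2 `O=C1O[C@@H](CSc2cccs2)CN1c1ccc(-n2cc(-c3ccccn3)cn2)c(F)c1`: > 400 ug/mL (a limit of the assay)
compound 3 `CN(C)S(=O)(=O)NC[C@H]1CN(c2ccc(-n3cc(-c4ccccn4)cn3)c(F)c2)C(=O)O1`: 158 ug/mL

In an ADME assay on L02 cells (Homo sapiens) for cytotoxicity, read by MTT assay, with a stated time of 48 h (a higher number here means a weaker inhibitor, a lower number a stronger inhibitor), compound 1 gives 70 ug/mL and compound 3 gives 158 ug/mL. Compound 2 reaches only > 400 ug/mL, which is a limit of the assay and not a number (the limit of > 400 ug/mL in this assay, at which 1 of the 3 values shown sits). Compound 3 thus holds the higher of the two numbers, its nearest neighbour being compound 1: a 2.3-fold higher number from compound 1 to compound 3 (0.35 log units; beyond the scatter). The other steps are an at least 2.5-fold lower number from compound 2 to compound 3 (0.40 log units; beyond the scatter) and an at least 5.7-fold higher number from compound 1 to compound 2 (0.75 log units; beyond the scatter).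

Compound 4 `NC(=O)[C@H]1CN(c2ccc(-n3cc(-c4ccccn4)cn3)c(F)c2)C(=O)O1` differs from compound 3 in one place: carbamoyl in place of ((dimethylsulfamoyl)amino)methyl on a saturated ring carbon. Within the data shown here, all three measured steps exchange one large substituent for another on the saturated chain carbon; none removes the chain and leaves a small group on the ring carbon itself, so no measured step bears directly on this change. The three numbers spread over a modest range, and the group entering is the smallest seen in the series. The expectation for compound 4 is therefore a step in this assay of a 1.3-fold higher number from compound 3 to compound 4 (0.10 log units; within the scatter), not confidently beyond the scatter in either direction. Compound 4 is estimated at 200 ug/mL, within 80 ug/mL to 400 ug/mL, with a fair chance that only a limit is reported.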

Compound 4, half-maximal inhibitory concentration: 119 ug/mL
For compound 4 the middle estimate is 1.7-fold (0.23 log units) above the measured one, and the stated range covers the measured number.
By their numbers in this assay, from the lowest: compounds 1, 4 and 3 (each within the scatter of the next, the first and the last beyond it). At a limit, above all of these: compound 2.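

In this assay, on the saturated ring carbon next to the ring oxygen, carbamoyl (3 heavy atoms) in place of ((dimethylsulfamoyl)amino)methyl (8 heavy atoms) leaves the result within the scatter (a 1.3-fold lower number from compound 3 to compound 4 (0.12 log units; within the scatter)). The same holds against the (4-methylpiperazin-1-yl)methyl group (a 1.7-fold higher number from compound 1 to compound 4 (0.23 log units; within the scatter)), so compound 4 shows that a chain on this ring carbon is not needed for a value in the range of compound 1 and compound 3, even though those two lie beyond the scatter of each other. The step from the ((thiophen-2-yl)sulfanyl)methyl group (an at least 3.3-fold lower number from compound 2 to compound 4 (0.52 log units; beyond the scatter)) is the only one of the three beyond the scatter, and it rests on a limit of the assay for compound 2, not a number: the limit of > 400 ug/mL in this assay, at which 1 of the 4 values shown sits.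

From the compounds shown here alone, it remains open whether this result belongs to carbamoyl itself or extends to other small groups on the same carbon, such as a carboxylic acid, an aminomethyl group or a hydroxymethyl group. Also open is how a longer chain ending in carbamoyl would compare with compound 4, and the compounds shown offer no direct test of that.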